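A few compounds are considered here, and "the series" means these few. Any claim that something is new, unique, unknown or untested is made for them only; others in the source may bear on it.

Compound 1 `CCCCCC(CCO)n1cnc2c(N)nc(Cl)nc21`: > 50000 nM (a limit)
Compound 2 `CCCCCCCCCCCC(CCO)n1cnc2c(N)ncnc21`: 11600 nM

Going by the values given here, in a functional assay on SW480 cells (Homo sapiens) for antiproliferative activity, read by MTT assay, with a stated time of 48 h (a lower number here means a stronger inhibitor, a higher number a weaker inhibitor), compound 2 gives 11600 nM, the only actual number so far. Compound 1 reads > 50000 nM, which is a limit of the assay and not a number. With a single number and a single limit, there is no ladder of values on which to rank compound 2 more finely.

The next compound, compound 3 `CCCCCCCCCCCC(CCO)n1cnc2c(N)nc(Cl)nc21`, has chloro in place of hydrogen on an aromatic carbon, between two ring nitrogen atoms, of compound 2: chloro in place of hydrogen on an aromatic carbon. Among the compounds with values here, no measured pair shows this change alone, so the data give no direct size for it. The expectation is therefore no step beyond the usual scatter, and the estimated step, a 1.2-fold lower number from compound 2 to compound 3 (0.06 log units; within the scatter), is small. For compound 3 the expected value is 10000 nM, with an estimated range from 4000 nM to 30000 nM.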

Compound 3, half-maximal inhibitory concentration: 17800 nM
For compound 3 the middle estimate is 1.8-fold (0.25 log units) below the measured one; the range from low to high includes it.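

Swapping hydrogen for chloro on this aromatic carbon, between two ring nitrogen atoms, gives a 1.5-fold higher number from compound 2 to compound 3 (0.19 log units; within the scatter) in this assay, so with the longer chain in place this swap cannot be told apart from repeat-to-repeat noise. The chain makes a clearer difference in the chloro series: hexyl in place of hydrogen on a saturated chain carbon, six bonds along the chain from an aromatic nitrogen, gives an at least 2.8-fold lower number from compound 1 to compound 3 (0.44 log units; beyond the scatter). That step is only a minimum because compound 1 stands at a limit and not at a number: the limit of > 50000 nM in this assay, at which 1 of the 3 values shown sits.

Going by these compounds, whether a different group on this aromatic carbon, such as an amine or a methoxy group, would read differently from chloro remains open. So does whether a still longer chain would lower the number further.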